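Dimethoxyphenyl in place of phenyl on the amide series

This account rests on a few compounds, and the source may have more. Where it says the series, first, only, none or still open, it means among the compounds named here.

Measured in a functional assay on NCI-H460 cells (Homo sapiens) for cytotoxicity, read by MTT assay, with a stated time of 72 h; a higher number here means a weaker inhibitor, a lower number a stronger inhibitor:
Compound 1 `COc1cc2c(Oc3ccc(NC(=O)c4cc(-c5ccccc5)ccn4)cc3F)ccnc2cc1OCCCN1CCN(C)CC1`: 91 nM
Compound 2 `COc1ccc(-c2ccnc(C(=O)Nc3ccc(Oc4ccnc5cc(OCCCN6CCCCC6)c(OC)cc45)c(F)c3)c2)cc1`: 200 nM

For the measured compounds named here, compound 1 holds the lower of the two numbers; compound 2 sits higher, beyond the scatter, but it differs from compound 1 in more than one place, so no single step is assigned. Compound 3 `COc1ccc(-c2ccnc(C(=O)Nc3ccc(Oc4ccnc5cc(OCCCN6CCN(C)CC6)c(OC)cc45)c(F)c3)c2)c(OC)c1` remains unmeasured; it carries 2,4-dimethoxyphenyl in place of phenyl on an aromatic carbon. Going by the values given here, no measured pair isolates this change. The step of a 1.6-fold higher number from compound 1 to compound 3 (0.22 log units; within the scatter) is expected to be small, toward a higher number, possibly within the scatter. For compound 3 the expected value in this assay is 150 nM, in the range 50 nM to 450 nM.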

Compound 3, half-maximal inhibitory concentration: 430 nM
Compound 3: the middle estimate sits 2.9-fold (0.46 log units) below what was measured; measured number inside the range.
By their numbers in this assay, from the lowest: compound 1; then compound 2; then compound 3.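

In this assay, for the compounds shown here, the change from phenyl to 2,4-dimethoxyphenyl opposite the ring nitrogen gives a 4.7-fold higher number from compound 1 to compound 3 (0.67 log units; beyond the scatter) and so provides the first isolated step at this position, one beyond the scatter. The position is therefore not indifferent to this change, and the 2,4-dimethoxyphenyl compound is the weaker inhibitor of the pair. No evidence at hand bears on the reason for this step.

Open, going by these compounds, is whether either methoxy group alone carries the loss. Also open, on these data alone, is how a fluorine atom or an amine on the phenyl ring would compare.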